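Ring-amine benzyl step from compound 3 to compound 4

The source may report more compounds than this note shows. Statements on the series, on what has been measured and on what is new or still open speak of the compounds shown alone.

Measured in an in vitro ADME assay on microsomes from liver (Mus musculus) for pharmacokinetics, read by LC-MS, with a stated time of 10 min, tested at 1 uM; a higher number here means faster removal of the compound, a lower number slower removal
compound 1 `CN1C[C@H](C(=O)Nc2ccc(F)c(Cl)c2)[C@@H](c2ccc(/C=C/C(=O)Nc3ccccc3N)cc2)C1` 34 mL/min/kg
compound 2 `CN1C[C@H](C(=O)NC2CC2)[C@@H](c2ccc(/C=C/C(=O)Nc3ccccc3N)cc2)C1` 7 mL/min/kg
compound 3 `CC(C)N1C[C@H](C(=O)Nc2ccc(Cl)cc2)[C@@H](c2ccc(/C=C/C(=O)Nc3ccccc3N)cc2)C1` 38 mL/min/kg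

Compound 3 lies within the scatter of compound 1, and compound 2 has the lower number, beyond the scatter. Compound 4 `Nc1ccccc1NC(=O)/C=C/c1ccc([C@H]2CN(Cc3ccccc3)C[C@@H]2C(=O)Nc2ccc(Cl)cc2)cc1` carries benzyl in place of isopropyl on an amine nitrogen in a ring. For the measured compounds named here, the only measured step (a 4.9-fold lower number from compound 1 to compound 2 (0.69 log units; beyond the scatter)) changes an amide-type nitrogen, so it does not speak directly to this change. Compound 1 and compound 3 also differ on the amine nitrogen in a ring, yet their values stay within the scatter. The estimated step (a 1.2-fold higher number from compound 3 to compound 4 (0.07 log units; within the scatter)) is not expected to exceed the scatter. For compound 4 the expected value in this assay is about (45 mL/min/kg), with an estimated range from (22 mL/min/kg) to (90 mL/min/kg).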

Compound 4, clearance: 81 mL/min/kg
Compound 4: the middle estimate sits 1.8-fold (0.26 log units) below what was measured; measured number inside the range.
By their numbers in this assay, from the lowest: compound 2; then compounds 1 and 3 (each within the scatter of the next); then compound 4.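

In this assay, the amine nitrogen in a ring responds to substitution: benzyl in place of isopropyl gives a 2.1-fold higher number from compound 3 to compound 4 (0.33 log units; beyond the scatter) with the rest of the structure unchanged. This modest step is the only single-place change at this position shown, so it rests on one pair of compounds. No measurement shown accounts for the step. Still open, from the compounds shown here alone, is how a hydrogen, a methyl or a benzyl bearing a carboxylic acid would behave at this nitrogen. Also open, going by these compounds, is whether the step holds with the cyclopropyl amide of compound 2.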